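The compounds below may be only part of what the source reports. "The series", "measured", "known", "first", "only" and "open" are said of these compounds alone.

Working notes on the cinnamamide series in a functional assay on SH-SY5Y cells (Homo sapiens) for cytotoxicity, read by MTT assay, with stated times of 24 h and 4 h; a lower number here means that less compound is needed, a higher number that more compound is needed for the effect.

Compound 1 `COc1cc(CNC(=O)/C=C/c2ccccc2)ccc1OCc1nc(C)c(C)nc1C` carries the (3,5,6-trimethylpyrazin-2-yl)methyl ether on the benzylamine side only; in this assay compound 1 gives 7310 nM. Compound 2 `COc1cc(CNC(=O)/C=C/c2ccc(OCc3nc(C)c(C)nc3C)cc2)ccc1O` places the same ether on the cinnamoyl side and leaves a free phenol on the benzylamine side; compound 2 gives 5370 nM. Compound 3 `COc1cc(CNC(=O)/C=C/c2ccc(O)cc2)ccc1OCc1nc(C)c(C)nc1C` keeps the ether of compound 1 and adds a phenol to the cinnamoyl ring; compound 3 gives 3740 nM. Compound 3 holds the lowest of the three numbers, yet the step of a 2.0-fold lower number from compound 1 to compound 3 (0.29 log units; within the scatter) is within the scatter, and the numbers of compound 2 and compound 3 are likewise within the scatter of each other, so no ranking among the three is supported.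

Compound 4 `COc1cc(CNC(=O)/C=C/c2ccc(OCc3nc(C)c(C)nc3C)cc2)ccc1OCc1nc(C)c(C)nc1C` is the next step: (3,5,6-trimethylpyrazin-2-yl)methyl in place of hydrogen on an oxygen on an aromatic ring. Within the data shown here, no measured pair shows this exact change. Among the measured compounds shown here, the only measured step, from compound 1 to compound 3, touches the same oxygen but is the reverse kind of change, and it stayed within the scatter. With both measured neighbours of compound 3 within the scatter, the step of a 1.5-fold higher number from compound 3 to compound 4 (0.17 log units; within the scatter) is expected to be small, with no direction beyond the scatter. Compound 4 is therefore estimated at 5500 nM, between 2200 nM and 14000 nM.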

Compound 4, half-maximal effective concentration: 7770 nM
Beside the measured number, compound 4's estimate is 1.4-fold (0.15 log units) below it, and the stated range covers the measured number.
By their numbers in this assay, from the lowest: compounds 3, 2, 1 and 4 (each within the scatter of the next, the first and the last beyond it).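

In this assay, among these compounds, the change of (3,5,6-trimethylpyrazin-2-yl)methyl in place of hydrogen on an oxygen on an aromatic ring gives a 2.1-fold higher number from compound 3 to compound 4 (0.32 log units; beyond the scatter) and is the first step to pass the scatter, if only modestly. Among the compounds shown here, the same change at the other oxygen gives a 1.4-fold higher number from compound 2 to compound 4 (0.16 log units; within the scatter) so only one of the two steps of this change clears the scatter, and the series now shows that the oxygen carrying the change matters to how far the step can be read. The remaining step reads a 1.1-fold higher number from compound 1 to compound 4 (0.03 log units; within the scatter) and so shows no readable difference, while no measurement at hand bears on the reason for any of these steps.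

Open, from the compounds shown here alone, is whether a plain methyl ether or a 2-(dimethylamino)ethyl ether on that oxygen would read like the hydroxy of compound 3 or like the (3,5,6-trimethylpyrazin-2-yl)methoxy of compound 4. Also open, going by these compounds, is where the core would stand with hydroxy on both oxygens, which would test the two steps of this change from a common point.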